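The source may hold more compounds than are shown below. What is called first, only, known or untested is meant among the compounds shown, and "the series" means these compounds.

Measured so far in an assay on HEK293 cells for binding affinity to prostaglandin E2 receptor EP3 subtype (Homo sapiens); a lower number here means a stronger inhibitor, a higher number a weaker inhibitor:

- compound 1, `O=C(O)/C=C/c1ccccc1-c1ccc(Cl)c(Cl)c1`: 1600 nM
- compound 2, `O=C(O)/C=C/c1ccccc1-c1cccc(-c2ccccc2OCc2ccccc2)c1`: 84 nM
- compound 3, `O=C(O)CCc1ccccc1-c1ccc(-c2ccccc2OCc2ccccc2)s1`: 520 nM

Compound 2 gives the lowest number of the three; the numbers of compound 3 and of compound 1 both lie clearly higher, beyond the usual scatter. Compound 4, `CC(Cc1ccccc1-c1cccc(-c2ccccc2OCc2ccccc2)c1)C(=O)O`, has not been measured in this assay. It differs from compound 2 in one place: 2-carboxypropyl in place of 2-carboxyethenyl on an aromatic carbon. Within the data shown here, no pair of measured compounds shows this same change on an otherwise identical core, so no direct step size is available; compound 3 carries a saturated acid chain on a different core and stands well above compound 2, which is the only hint at hand. The step from compound 2 to compound 4 is expected to be a loss of some size rather than none, a 3.0-fold higher number from compound 2 to compound 4 (0.47 log units; beyond the scatter), though a value still within reach of compound 2 cannot be ruled out. For compound 4 the estimate in this assay is 250 nM, with a range from 80 nM to 800 nM.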

Compound 4, inhibition constant: 820 nM
Compound 4: middle estimate off by 3.3-fold (0.52 log units), on the low side, and the stated range ends below it.
By their numbers in this assay, from the lowest: compound 2; then compounds 3, 4 and 1 (each within the scatter of the next, the first and the last beyond it).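

In this assay, among these compounds, 2-carboxypropyl in place of 2-carboxyethenyl on an aromatic carbon ortho to a large group gives a 9.8-fold higher number from compound 2 to compound 4 (0.99 log units; beyond the scatter), the first single-place step, so this position is sensitive to the form of the acid-bearing chain. The change removes the chain's double bond and also raises the count from 5 to 6 heavy atoms, and this one step cannot separate those two differences. Nothing available explains the loss.

Still open, going by these compounds, is whether the double bond or the extra carbon accounts for the step, a question that a 2-carboxyethyl chain on the shared core would address. Also open, on these data alone, is whether this position tolerates a longer chain ending in a carboxylic acid, or a tetrazole in place of the carboxylic acid.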